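A few compounds are considered here, and "the series" means these few. Any claim that something is new, unique, unknown or untested is made for them only; others in the source may bear on it.

Working notes on the series.

Among the compounds with values here, compound 2 `COc1ccc(F)c([C@H]2CC[C@H](COc3cccc([C@H](C4CC4)[C@@](C)(F)C(=O)O)c3)CC2)c1` stands lowest of the two numbers so far in a functional assay on cells for agonist activity at Free fatty acid receptor 1 (Homo sapiens), read by HTRF and inositol phosphate accumulation, with a stated time of 90 min; on this read-out higher numbers stand for an effect only at larger amounts of compound and lower numbers for an effect already at smaller amounts: compound 2 gives 3.1 nM, and its nearest neighbour is compound 1 `COc1ccc(F)c([C@H]2CC[C@H](COc3cccc([C@H](C4CC4)[C@@H](F)C(=O)O)c3)CC2)c1`, which in this assay gives 20 nM. Within the data shown here, the only step measured in this set runs a 6.5-fold lower number from compound 1 to compound 2 (0.81 log units; beyond the scatter), the 1-carboxy-1-fluoroethyl in place of carboxy(fluoro)methyl on the saturated chain carbon bound to an aromatic carbon and a saturated ring carbon.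

Compound 3 `COc1ccc(F)c([C@H]2CC[C@H](COc3cccc([C@H](C4CC4)[C@](C)(F)C(=O)O)c3)CC2)c1` differs from compound 2 as follows: the two compounds have the same atoms and bonds and differ only in configuration as drawn: 1 of 4 stereo elements differ; a stereocentre at a saturated chain carbon is drawn R in compound 2 and S in compound 3. The two compounds have the same atoms and bonds and differ only in configuration as drawn; one of four stereo elements differs, a stereocentre at a saturated chain carbon drawn R in compound 2 and S in compound 3.

Among the measured compounds shown here, no measured step in the set bears directly on this change; the only step, from compound 1 to compound 2, changes a group rather than a configuration, and the set holds no pair of epimers. The size of the step cannot be read from the measured data. With the drawn configuration of compound 2 the best performer so far, the expectation for compound 3 is a higher number in this assay, of unsettled size, the step of a 9.7-fold higher number from compound 2 to compound 3 (0.99 log units; beyond the scatter) being an estimate only. Compound 3 is estimated at 30 nM, within a range from 5 nM to 300 nM.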

Compound 3, half-maximal effective concentration: 89 nM
Estimate against measurement, compound 3: 3.0-fold (0.47 log units) below, within the range that was stated.
By their numbers in this assay, from the lowest: compound 2; then compound 1; then compound 3.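

In this assay, a change in drawn configuration at one saturated chain carbon, with no atom or bond altered, gives a 29-fold higher number from compound 2 to compound 3 (1.46 log units; beyond the scatter), so this position is sensitive to stereochemistry as well as to substitution. Methyl in place of hydrogen on this carbon also has no single direction of its own: with the configuration drawn R it gives a 6.5-fold lower number from compound 1 to compound 2 (0.81 log units; beyond the scatter), and with the configuration drawn S it gives a 4.5-fold higher number from compound 1 to compound 3 (0.65 log units; beyond the scatter). The gap between the two methyl compounds therefore rests on this one stereocentre, and the ground for that reading is: the fact that compounds 2 and 3 differ only in the configuration as drawn

Whether the R-drawn configuration keeps its advantage with a larger group such as ethyl in place of methyl, or with hydroxyl in place of fluorine, cannot be told from the compounds shown. Also open, from the compounds shown here alone, is how much the configuration at the other stereocentres matters, including the saturated chain carbon bound to an aromatic carbon and a saturated ring carbon, and whether compound 1, which carries hydrogen in place of methyl, would show a comparable gap between its configurations.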